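A few compounds are considered here, and "the series" means these few. Any claim that something is new, unique, unknown or untested is made for them only; others in the source may bear on it.

Compound 1 `O=C(NC1CCC(CN2CCN(c3cc(=O)c4cc(C(F)(F)F)cc([N+](=O)[O-])c4s3)CC2)CC1)c1ccccc1`: > 1.55 h (a limit)
Compound 2 `O=C(OC1CCC(CN2CCN(c3cc(=O)c4cc(C(F)(F)F)cc([N+](=O)[O-])c4s3)CC2)CC1)c1ccncc1`: 0.0817 h
Compound 3 `O=C(OC1CCC(CN2CCN(c3cc(=O)c4cc(C(F)(F)F)cc([N+](=O)[O-])c4s3)CC2)CC1)c1ccco1`: < 0.075 h (a limit)

In an ADME assay on cells (Hepatocyte, Mus musculus) for metabolic stability (on this read-out higher numbers stand for a longer-lived compound and lower numbers for a shorter-lived compound), compound 3 gives < 0.075 h, which is a limit and not a number. It stands with compound 2, far under compound 1.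

Compound 4 `O=C(OC1CCC(CN2CCN(c3cc(=O)c4cc(C(F)(F)F)cc([N+](=O)[O-])c4s3)CC2)CC1)C1CCCCC1` brings (cyclohexyl in place of furan-2-yl on a carbonyl carbon), cyclohexyl in place of furan-2-yl on a carbonyl carbon. Within the data shown here, the one measured swap on that carbon is an at least 1.0-fold lower number from compound 2 to compound 3 (0.03 log units; that floor lies within the scatter), and its floor lies within the scatter. The large steps came with the loss of the benzamido group: an at least 18-fold lower number from compound 1 to compound 2 (1.27 log units; beyond the scatter) and an at least 20-fold lower number from compound 1 to compound 3 (1.31 log units; beyond the scatter). Compound 4 lacks that group too, so it is expected to stay short-lived, as compound 2 does at 0.0817 h. The expected step is an at least 1.2-fold higher number from compound 3 to compound 4 (0.07 log units; that floor lies within the scatter), nothing beyond the scatter. For compound 4 the estimate is 0.09 h, within an expected range of 0.05 h to 0.25 h.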

Compound 4, half-life: 0.0783 h
The estimate for compound 4 lay 1.1-fold (0.06 log units) above the measured number; measured number inside the range.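

At the carbonyl carbon, the non-aromatic cyclohexyl now stands with the aromatic rings, and this assay does not separate them: a 1.0-fold lower number from compound 2 to compound 4 (0.02 log units; within the scatter). Compound 3 can be compared only through a floor because its value is a limit: the limit of < 0.075 h in this assay, at which 1 of the 4 values shown sits. That step is an at least 1.0-fold higher number from compound 3 to compound 4 (0.01 log units; that floor lies within the scatter), while the gap to benzamido remains large: an at least 19-fold lower number from compound 1 to compound 4 (1.29 log units; beyond the scatter).

Compound 1 differs from compound 4 in both the linking atom and the ring, so the compounds shown do not separate these two changes. From the compounds shown here alone, how an ethyl chain or an amine on that carbonyl carbon would behave also stays open.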